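A few compounds are considered here, and "the series" means these few. Any claim that something is new, unique, unknown or untested is made for them only; others in the source may bear on it.

Measured in a functional assay on aorta (strain Wistar) for inhibition, with Thoracic aorta (Rattus norvegicus) as the target; on this read-out lower numbers stand for stronger inhibition and higher numbers for weaker inhibition:

Compound 1, `CCOc1nc(-c2cc3ccccc3o2)cc(-c2ccccc2)c1C#N`: 310000 nM
Compound 2, `CCOc1nc(-c2cc3ccccc3o2)cc(-c2cccc3ccccc23)c1C#N`: 344000 nM
Compound 3, `COc1nc(-c2cc3ccccc3o2)cc(-c2ccc3ccccc3c2)c1C#N`: 320000 nM

All three numbers lie close together. Compound 3 stands second highest of the three, but its gaps to compound 1 and to compound 2 are both within the scatter of repeated measurements, so on these data the three compounds cannot be told apart. For the measured compounds named here, the one directly compared change, a 1.1-fold higher number from compound 1 to compound 2 (0.05 log units; within the scatter), is likewise within the scatter.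

Compound 4, `CCOc1nc(-c2cc3ccccc3o2)cc(-c2ccc3ccccc3c2)c1C#N`, has not yet been measured. It differs from compound 3 in one place: methyl in place of hydrogen on a saturated chain carbon bound to an oxygen on an aromatic ring. Going by the values given here, no measured pair shows this particular change; the only measured step, from compound 1 to compound 2, concerns a different part of the molecule and so does not bear on the step to compound 4. Compound 1 and compound 2 already carry the ethoxy group and show no separation from compound 3 with its methoxy group, which suggests that the choice between the two has little effect here.

Compound 4 is therefore expected to give 320000 nM in this assay, between 160000 nM and 640000 nM. The expected step from compound 3 to compound 4 is no change at the digits printed from compound 3 to compound 4 (within the scatter), which is estimated to stay within the scatter.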

Compound 4, half-maximal inhibitory concentration: 423000 nM
Beside the measured number, compound 4's estimate is 1.3-fold (0.12 log units) below it; measured number inside the range.
By their numbers in this assay, from the lowest: compounds 1, 3, 2 and 4 (each within the scatter of the next).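

In this assay, for the compounds shown here, this is the first direct reading of the change from methoxy to ethoxy: a 1.3-fold higher number from compound 3 to compound 4 (0.12 log units; within the scatter). Going by these compounds alone, putting a methyl on this saturated chain carbon bound to an oxygen on an aromatic ring therefore gives a step that cannot be told apart from repeat-measurement noise, which the earlier compounds could suggest only indirectly. The two further steps on the aromatic carbon read the same way, with a 1.2-fold higher number from compound 2 to compound 4 (0.09 log units; within the scatter) for naphthalen-2-yl in place of naphthalen-1-yl and a 1.4-fold higher number from compound 1 to compound 4 (0.13 log units; within the scatter) for naphthalen-2-yl in place of phenyl, and no information is available to explain why these four compounds sit so close together.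

The compounds shown leave open whether any group at this position can move the number beyond the scatter, for example a longer chain such as butoxy or a chain ending in an amine or a carboxylic acid. They also leave open whether the aromatic group could do so if it carried a substituent such as a hydroxyl or an amine, since every aromatic group shown here is an unsubstituted phenyl or naphthyl.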